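The source may hold more compounds than are shown below. What is called first, only, known or untested is meant among the compounds shown, and "the series" means these compounds.

Three compounds share one core and differ only in the benzyl group attached to the amine nitrogen. Compound 1 `CCN(CCCOc1ccc(C(=O)/C=C/c2ccc(N(C)C)cc2)c(O)c1)Cc1ccccc1` carries an unsubstituted ring and gives 82600 nM in an assay on isolated protein for inhibition of Amine oxidase [flavin-containing] A (Homo sapiens); on this read-out lower numbers stand for stronger inhibition and higher numbers for weaker inhibition. Compound 2 `CCN(CCCOc1ccc(C(=O)/C=C/c2ccc(N(C)C)cc2)c(O)c1)Cc1ccccc1OC` gives 26300 nM in this assay, and compound 3 `CCN(CCCOc1ccc(C(=O)/C=C/c2ccc(N(C)C)cc2)c(O)c1)Cc1ccccc1N(C)C` gives 23600 nM in this assay. On the numbers shown compound 3 sits at the low end, with compound 2 within the scatter of it and compound 1 beyond it. Two steps added a group to the ring: a 3.1-fold lower number from compound 1 to compound 2 (0.50 log units; beyond the scatter) and a 3.5-fold lower number from compound 1 to compound 3 (0.54 log units; beyond the scatter). Exchanging one group for the other, a 1.1-fold lower number from compound 2 to compound 3 (0.05 log units; within the scatter), moved nothing beyond the scatter. Compound 4 `CCN(CCCOc1ccc(C(=O)/C=C/c2ccc(N(C)C)cc2)c(O)c1)Cc1ccc(N(C)C)cc1` keeps the same atoms as compound 3 and differs only in where the group sits: 4-(dimethylamino)phenyl in place of 2-(dimethylamino)phenyl on a saturated chain carbon bound to an amine nitrogen. Within the data shown here, no measured step tests a move of this kind; the steps that bear on it show that adding either group helped modestly and that the choice between them made no difference beyond the scatter. Compound 4 is therefore expected to stay close to compound 3, with a 1.1-fold higher number from compound 3 to compound 4 (0.03 log units; within the scatter), and its estimated value is 25000 nM, within a range from 8000 nM to 80000 nM.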

Compound 4, half-maximal inhibitory concentration: 57500 nM
The estimate for compound 4 lay 2.3-fold (0.36 log units) below the measured number; the range from low to high includes it.
By their numbers in this assay, from the lowest: compounds 3 and 2 (each within the scatter of the next); then compounds 4 and 1 (each within the scatter of the next).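

In this assay, where the group sits on the ring turns out to matter: the move to 4-(dimethylamino)phenyl gives a 2.4-fold higher number from compound 3 to compound 4 (0.39 log units; beyond the scatter), a step beyond the scatter, whereas exchanging methoxy for dimethylamino had moved nothing beyond it. The new group also differs from 2-methoxyphenyl, with a 2.2-fold higher number from compound 2 to compound 4 (0.34 log units; beyond the scatter), so the two earlier ring substituents stand together, apart from compound 4. Adding dimethylamino to the ring no longer helps in every case: a 1.4-fold lower number from compound 1 to compound 4 (0.16 log units; within the scatter) leaves compound 4 within the scatter of the unsubstituted ring, unlike the two earlier additions. Going by these compounds, whether methoxy responds in the same way to a move around the ring stays open, as does what a chlorine or a carboxylic acid on that ring would do. Nothing available here accounts for the effect of the move.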